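The compounds below may be only part of what the source reports. "The series", "measured", "known", "first", "only" and "open" are said of these compounds alone.

Measured in an assay on isolated protein for inhibition of Rho-associated protein kinase 2 (Homo sapiens), read by scintillation counting, radiometric assay and 33P incorporation, with a stated time of 40 min, in the presence of a further agent that is not named here; a lower number here means a stronger inhibitor, a higher number a weaker inhibitor:
compound 1 `CC(C)(C)c1ccc(C(=O)Nc2cccc(NC(=O)COc3ccc4c(=O)ccoc4c3)c2)cc1`: 34 nM
compound 2 `O=C(COc1ccc2c(=O)ccoc2c1)Nc1cccc(NS(=O)(=O)c2ccc(C(F)(F)F)cc2)c1`: 6890 nM
compound 3 `O=C(COc1ccc2c(=O)ccoc2c1)Nc1cccc(NS(=O)(=O)c2ccc(OC(F)(F)F)cc2)c1`: 1280 nM

Compound 1 stands lowest of the three numbers, well beyond the scatter from compound 3 and still further from compound 2. Compound 4 `NCc1ccc(C(=O)Nc2cccc(NC(=O)COc3ccc4c(=O)ccoc4c3)c2)cc1` differs from compound 1 by aminomethyl in place of tert-butyl on an aromatic carbon. For the measured compounds named here, the single measured step, a 5.4-fold lower number from compound 2 to compound 3 (0.73 log units; beyond the scatter), concerns a different substituent swap and does not bear on the change from compound 1 to compound 4. Going by the values given here, no measured pair tests this change, so the expectation rests on compound 1 alone, with room for a modest move in either direction. Compound 4 is expected near 60 nM, estimated between 15 nM and 300 nM. The expected step is a 1.8-fold higher number from compound 1 to compound 4 (0.25 log units; within the scatter), within or just beyond the scatter.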

Compound 4, half-maximal inhibitory concentration: 66 nM
Estimate against measurement, compound 4: 1.1-fold (0.04 log units) below; the range from low to high includes it.
By their numbers in this assay, from the lowest: compounds 1 and 4 (each within the scatter of the next); then compound 3; then compound 2.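

In this assay, aminomethyl in place of tert-butyl, para to a large group, gives a 1.9-fold higher number from compound 1 to compound 4 (0.29 log units; within the scatter). This position therefore holds two quite different groups without a change beyond the scatter, so tert-butyl is not needed here to keep the number of compound 1, even though aminomethyl has fewer heavy atoms and brings a hydrogen-bond donor and acceptor. No measurement available here explains this result.

Still open, on these data alone, is how an aminoethyl chain, a dimethylaminomethyl group or a carboxylic acid would read at this position.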